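A few compounds are considered here, and "the series" means these few. Any claim that something is new, unique, unknown or untested is made for them only; others in the source may bear on it.

Compound 1 `CC(=O)O[C@@H]1OC(=O)[C@](C)(C(C)=O)[C@@H]1C` is the shared core of this small set. In a functional assay on MCF7 cells (Homo sapiens) for cytotoxicity, read by MTT assay (on this read-out higher numbers stand for weaker inhibition and lower numbers for stronger inhibition), compound 1 gives 6000 nM. Of the two plain numbers shown, compound 1 carries the higher one; its nearest neighbour is compound 3, and the two lie within the scatter of each other.

Compound 2 `CC(=O)O[C@@H]1OC(=O)[C@](OC(C)=O)(C(C)=O)[C@@H]1C` carries acetoxy in place of methyl on a saturated ring carbon. In this assay compound 2 reaches only the limit of the assay, > 50000 nM, a boundary rather than a number, so the change from compound 1 is known only as a bound: an at least 8.3-fold higher number from compound 1 to compound 2 (0.92 log units; beyond the scatter).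

Compound 3 `CC(=O)O[C@@H]1OC(=O)[C@](C)(C(=O)CBr)[C@@H]1C` carries bromo in place of hydrogen on a saturated chain carbon bound to a carbonyl carbon. In this assay compound 3 gives 4000 nM, a shift that stays inside the scatter: a 1.5-fold lower number from compound 1 to compound 3 (0.18 log units; within the scatter).

Compound 4 `CC(=O)[C@@]1(C)C(=O)O[C@@H](OC(=O)c2ccccc2)[C@H]1C` has not yet been measured. It differs from compound 1 by phenyl in place of methyl on a carbonyl carbon. For the measured compounds named here, neither measured step touches this carbonyl carbon, so the two steps give no direct guide; the only change that moved the number beyond the scatter, toward compound 2, sat on a ring carbon. Compound 4 is therefore expected to sit close to compound 1, with an expected step of a 1.2-fold lower number from compound 1 to compound 4 (0.08 log units; within the scatter). The estimate for compound 4 in this assay is 5000 nM, with a range from 1500 nM to 20000 nM.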

Compound 4, half-maximal inhibitory concentration: 3000 nM
For compound 4 the middle estimate is 1.7-fold (0.22 log units) above the measured one; measured number inside the range.
By their numbers in this assay, from the lowest: compounds 4, 3 and 1 (each within the scatter of the next). At a limit, above all of these: compound 2.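

Compound 4 is the only compound shown that is changed at this carbonyl carbon, the one whose other neighbour is the oxygen next to a carbonyl group. In this assay, putting phenyl in place of methyl there gives a 2.0-fold lower number from compound 1 to compound 4 (0.30 log units; within the scatter), so this carbonyl carbon can carry a six-membered aromatic ring of 6 heavy atoms instead of a single-carbon methyl, and the number stays within the usual scatter of compound 1, unlike the ring-carbon change that produced compound 2, whose entry of > 50000 nM is a limit of the assay. Nothing given here bears on why phenyl and methyl read so alike at this place, so the result stands as an observation without an explanation.

The compounds shown leave open how far this tolerance extends, since only methyl and phenyl appear at this carbonyl carbon, and a longer chain such as hexyl, an amine or a phenyl ring carrying chloro or methoxy could read quite differently. They also leave open whether phenyl at this place combines with bromo on the chain carbon, as found in compound 3, to give a number beyond the scatter.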